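This account rests on a few compounds, and the source may have more. Where it says the series, first, only, none or still open, it means among the compounds named here.

Compound 1 `COc1cc2ncnc(Nc3ccc(OC(F)(F)F)cc3)c2cc1OCCCCC(=O)Nc1ccc(S(N)(=O)=O)cc1` gives 22500 nM in a functional assay on A-431 cells (Homo sapiens) for antiproliferative activity, read by MTT assay, with a stated time of 72 h; a higher number here means a weaker inhibitor, a lower number a stronger inhibitor.
Compound 2 `NS(=O)(=O)c1ccc(NC(=S)Nc2ccc3ncnc(Nc4cccc(C(F)(F)F)c4)c3c2)cc1` gives 21700 nM in this assay.
Compound 3 `NS(=O)(=O)c1ccc(NC(=S)Nc2ccc3ncnc(Nc4cccc(Br)c4)c3c2)cc1` gives 20700 nM in this assay.

All three numbers lie within the usual scatter of one another, so compound 3 is not set apart from compound 1 or compound 2 in this assay. Compound 4 `Cc1cccc(Nc2ncnc3ccc(NC(=S)Nc4ccc(S(N)(=O)=O)cc4)cc23)c1` differs from compound 3 in one place: methyl in place of bromo on an aromatic carbon. Among the compounds with values here, the one measured step that bears on this change is a swap at the same position, a 1.0-fold lower number from compound 2 to compound 3 (0.02 log units; within the scatter), which left the number essentially unchanged. Within the data shown here, no other step touches this position. Putting methyl in place of bromo is therefore expected to do little as well, so for compound 4 the step of a 1.0-fold higher number from compound 3 to compound 4 (0.01 log units; within the scatter) is estimated to stay within the scatter. Compound 4 is expected to give 21000 nM in this assay, within a range from 8000 nM to 55000 nM.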

Compound 4, half-maximal inhibitory concentration: 23800 nM
Beside the measured number, compound 4's estimate is 1.1-fold (0.05 log units) below it; measured number inside the range.
By their numbers in this assay, from the lowest: compounds 3, 2, 1 and 4 (each within the scatter of the next).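

Methyl now joins bromo and trifluoromethyl at this position on the aromatic ring, and in this assay the swaps read a 1.1-fold higher number from compound 3 to compound 4 (0.06 log units; within the scatter) and a 1.1-fold higher number from compound 2 to compound 4 (0.04 log units; within the scatter) and so stay within the scatter. Within the data shown here, the earlier compounds offered only one such swap, whereas three groups at this place now give numbers that cannot be told apart. No measurement shown explains why these swaps change so little.

From the compounds shown here alone, whether an amine, a carboxylic acid or a longer chain at this place would move the number remains open. So does whether these three groups would also match one another on the core of compound 1.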